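The source may hold more compounds than are shown below. What is called first, only, known or untested is meant among the compounds shown, and "the series" means these compounds.

Compound 1 `Cc1ccccc1S(=O)(=O)Nc1ccc(-c2nc3ccccc3o2)cc1`: in an ADME assay on HEK293 cells (Homo sapiens) for cytotoxicity, read by resazurin assay, with a stated time of 48 h (on this read-out higher numbers stand for lower toxicity in this test and lower numbers for higher toxicity in this test), compound 1 gives > 100000 nM, which is a limit of the assay and not a number.
Compound 2 `CS(=O)(=O)Nc1ccc2oc(-c3ccccc3)nc2c1`: in this assay compound 2 gives > 100000 nM, again a limit rather than a number.

Compound 2 thus stands at the limit of > 100000 nM in this assay, at which 2 of the 2 values shown sit. Compound 3 `O=S(=O)(Nc1ccc2oc(-c3ccccc3)nc2c1)c1ccc(Cl)cc1` is not yet measured; it differs from compound 2 by 4-chlorophenyl in place of methyl on a sulfonyl sulfur. For the measured compounds named here, no measured pair shows this kind of change, so no step beyond the usual scatter is expected in this assay. The expected step is a number no higher from compound 2 to compound 3 (the limit leaves the size open). Compound 3 is estimated at 100000 nM, with a range from 30000 nM to 300000 nM, and most likely another limit.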

Compound 3, half-maximal cytotoxic concentration: 65000 nM
Compound 3: the middle estimate sits 1.5-fold (0.19 log units) above what was measured, and the stated range covers the measured number.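

Swapping methyl for 4-chlorophenyl on the sulfonyl sulfur gives an at least 1.5-fold lower number from compound 2 to compound 3 (0.18 log units; that floor lies within the scatter), so this position can register a change in this assay, though the floor of that step does not by itself separate the two compounds. Compound 3 is the only one of the three that comes off the limit: the limit of > 100000 nM in this assay, at which 2 of the 3 values shown sit. From the compounds shown here alone, its true distance from compound 2 stays unknown, since compound 2 has only a limit.

Going by these compounds, whether the ring or its chlorine matters more stays open. So does how plain phenyl, or a chain ending in an amine or a carboxylic acid, would read on the sulfonyl sulfur.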